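The source may report more compounds than this note shows. Statements on the series, on what has been measured and on what is new or still open speak of the compounds shown alone.

Working notes on the series in an ADME assay on HEK293 cells (Homo sapiens) for cytotoxicity, with a stated time of 72 h; a lower number here means that less compound is needed, a higher number that more compound is needed for the effect. Compound 1, `C=C[C@@](C)(/C=C/c1ccc(OS(=O)(=O)c2ccc(C)cc2)cc1)CCC=C(C)C`, gives > 36600 nM, which is a limit and not a number. Compound 2, `C=C[C@@](C)(/C=C/c1ccc(O)cc1)CCC1OC1(C)C`, gives > 36600 nM, again a limit. Compound 3, `C=C[C@@](C)(/C=C/c1ccc(O)cc1)CCC(O)C(C)(C)O`, gives > 36600 nM, so it too stands only as a limit. The whole readout so far comes down to the limit of > 36600 nM in this assay, at which 3 of the 3 values shown sit.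

Next in line is compound 4, `C=C[C@@](C)(/C=C/c1ccc(O)cc1)CCCO`. Its difference from compound 3 is hydrogen in place of 1-hydroxy-1-methylethyl on a saturated chain carbon bound to an oxygen on a saturated carbon and a saturated chain carbon. Cut one bond further out, the same change reads 2,3-dihydroxy-3-methylbutyl to 2-hydroxyethyl.

For the measured compounds named here, the one measured step at this end of the chain is a step that the two limits leave unreadable from compound 2 to compound 3. Going by the values given here, it offers neither a size nor a direction to carry over to the present change, and no measured step has a readable size. Among the compounds with values here, with no sized step to draw on, no shift beyond the scatter is expected in this assay. The expected step, a step that the limit leaves unreadable from compound 3 to compound 4, is therefore a working estimate with little behind it, and a report of a limit alone is the likeliest outcome. For compound 4 the estimate is 40000 nM, with an expected range from 15000 nM to 80000 nM.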

Compound 4, half-maximal effective concentration: > 36600 nM
Compound 4: no number, only a limit (the forecaster's own chance of this, stated with the estimate: 80%); the middle value is on the limit's open side.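

Compound 4 gives > 36600 nM in this assay, which is a limit and not a number. Its steps from compound 2 and from compound 3 therefore cannot be read. The compounds shown leave open whether any change to the shared core gives a measurable value in this assay, since the whole readout still comes down to one limit: the limit of > 36600 nM in this assay, at which 4 of the 4 values shown sit.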